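Compound 4: a bromobenzyl in place of a bromophenyl

The source may hold more compounds than are shown below. What is called first, only, known or untested is meant among the compounds shown, and "the series" means these compounds.

Of the compounds shown here, three sharing one core have been measured in an assay on CHO cells for displacement of a labelled ligand from adenosine receptor A1 (Homo sapiens), read by scintillation counting, with a stated time of 90 min, in the presence of a further agent that is not named here; on this read-out higher numbers stand for weaker inhibition and lower numbers for stronger inhibition. Compound 1 `CCCn1c(=O)[nH]c2nc(-c3ccc(S(=O)(=O)N4CCN(c5ccc(Cl)cc5F)CC4)cc3)[nH]c2c1=O` gives only a limit of the assay, > 1000 nM. Compound 2 `CCCn1c(=O)[nH]c2nc(-c3ccc(S(=O)(=O)N4CCN(Cc5cccc(C)c5)CC4)cc3)[nH]c2c1=O` gives 795 nM. Compound 3 `CCCn1c(=O)[nH]c2nc(-c3ccc(S(=O)(=O)N4CCN(c5cccc(Br)c5)CC4)cc3)[nH]c2c1=O` again gives only a limit, > 1000 nM. The step of an at least 1.2-fold lower number from compound 1 to compound 2 (0.09 log units; that floor lies within the scatter) is a floor within the scatter. The step that the two limits leave unreadable from compound 1 to compound 3 cannot be read, because of the limit of > 1000 nM in this assay, at which 2 of the 3 values shown sit. The step of an at least 1.2-fold higher number from compound 2 to compound 3 (0.09 log units; that floor lies within the scatter) is likewise a floor within the scatter. Compound 3 thus stands at the limit together with compound 1, while compound 2 alone returns a number.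

Compound 4 `CCCn1c(=O)[nH]c2nc(-c3ccc(S(=O)(=O)N4CCN(Cc5ccc(Br)cc5)CC4)cc3)[nH]c2c1=O` differs from compound 3 by 4-bromobenzyl in place of 3-bromophenyl on an amine nitrogen in a ring. Among the measured compounds shown here, the steps that bear on this are the two that involve compound 2, the only compound carrying a benzyl on that ring nitrogen, namely an at least 1.2-fold lower number from compound 1 to compound 2 (0.09 log units; that floor lies within the scatter) and an at least 1.2-fold higher number from compound 2 to compound 3 (0.09 log units; that floor lies within the scatter); both are floors within the scatter and give no firm direction. Compound 4, which also carries a benzyl on that nitrogen, is therefore expected to lie near the number that compound 2 returned rather than at the limit, though a value beyond the limit cannot be excluded. The estimated step is an at least 1.1-fold lower number from compound 3 to compound 4 (0.07 log units; that floor lies within the scatter), so that compound 4 is expected at 850 nM, with a range from 300 nM to 2500 nM.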

Compound 4, inhibition constant: > 1000 nM
Compound 4: only a limit was reported; the forecaster's own chance of this, stated with the estimate: 35%; at least 1.1-fold (0.07 log units) between middle value and limit.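

In this assay compound 4 gives > 1000 nM, which is a limit of the assay and not a number. Among the compounds shown here, a benzyl on the amine nitrogen in the ring thus does not by itself bring a readable value, and the one step that can be read, an at least 1.2-fold higher number from compound 2 to compound 4 (0.09 log units; that floor lies within the scatter), gives only a floor for 4-bromophenyl in place of 3-methylphenyl on a saturated chain carbon bound to an amine nitrogen in a ring. The steps to compound 4 from the two aryl compounds cannot be read, because both ends of each step are limits: the limit of > 1000 nM in this assay, at which 3 of the 4 values shown sit.

From the compounds shown here alone, the change from compound 2 to compound 4 alters both the substituent and the place it holds on the aromatic ring, so it remains open whether a 3-bromobenzyl or a 4-methylbenzyl would read with compound 2 or with compound 4. Going by these compounds, it also remains open how this assay would read with a longer chain between the ring nitrogen and the aromatic ring, or with a carboxylic acid on the benzyl group.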